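Replacing a Methylphenyl Amide with a Small Ring Amide

This account rests on a few compounds, and the source may have more. Where it says the series, first, only, none or still open, it means among the compounds named here.

Measured compounds:
Compound 1, `Cc1cc(C)cc(NC(=O)COc2cc(C)nc3ccc(OC(F)(F)F)cc23)c1`: 6.79
Compound 2, `COc1ccc2nc(C)cc(OCC(=O)Nc3cccc(C)c3)c2c1`: 4.83

For the measured compounds named here, in a physicochemical assay for lipophilicity, read by HPLC, in phosphate buffer, measured as chromatographic lipophilicity, at pH 7.4 (a higher number here means a more lipophilic compound, a lower number a more polar compound), compound 2 gives 4.83, the lower of the two numbers known so far; compound 1 gives 6.79, a gap that lies beyond the scatter. Compound 3, `COc1ccc2nc(C)cc(OCC(=O)NC3CONC3=O)c2c1`, has not yet been measured. It keeps the shared core of compound 2 and differs in one place: a group of 6 heavy atoms (3 carbon, 1 nitrogen, 2 oxygen; one five-membered non-aromatic ring with 2 hetero atoms) in place of a group of 7 heavy atoms (7 carbon; one six-membered aromatic ring of carbon only), on an amide-type nitrogen. The group that enters carries 1 hydrogen-bond donor and 2 hydrogen-bond acceptors where the leaving 3-methylphenyl carried none, so in this assay a large step downward is expected, well beyond the scatter, starting from compound 2 at 4.83. For compound 3 the estimate in this assay is 2.4, between 1.6 and 3.2, an expected step of a number 2.43 log units lower from compound 2 to compound 3 (beyond the scatter).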

Compound 3, distribution coefficient: 0.79
For compound 3 the middle estimate is 1.61 log units above the measured one, outside the stated range (below it).
By their numbers in this assay, from the lowest: compound 3; then compound 2; then compound 1.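

In this assay, putting the five-membered non-aromatic ring with 2 hetero atoms in place of 3-methylphenyl on the amide-type nitrogen gives a number 4.04 log units lower from compound 2 to compound 3 (beyond the scatter) and makes compound 3 the lowest of the three compounds. For the compounds shown here, this is the first reading of a change in one place, showing that the group on this nitrogen alone can move the number by a large amount, whereas compound 1 and compound 2 differ in more than one place. Nothing measured here explains the size of this step.

This single step changes the ring size, the aromatic character, the hetero atoms and the hydrogen-bond counts together, so their separate shares cannot be read. On these data alone, what a cyclopentyl group or a simple methyl group on the same nitrogen would give also remains open.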